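The source may report more compounds than this note shows. Statements on the series, on what has been measured and on what is new or still open speak of the compounds shown alone.

Compound 1, `Cn1cc(-c2nn(Cc3ccc(C(=O)N4CCCCC4)cc3)c(=O)c3ccccc23)cn1`, gives 77100 nM in a functional assay on LoVo cells (Homo sapiens) for antiproliferative activity, read by MTT assay, with a stated time of 72 h; on this read-out lower numbers stand for stronger inhibition and higher numbers for weaker inhibition.
Compound 2, `CN1CCC(NC(=O)c2ccc(Cn3nc(-c4cnn(C)c4)c4ccccc4c3=O)cc2)CC1`, gives 83300 nM in this assay.

For the measured compounds named here, compound 2 holds the highest of the two numbers, with compound 1 as its only neighbour and the step of a 1.1-fold higher number from compound 1 to compound 2 (0.03 log units; within the scatter). Compound 3, `Cn1cc(-c2nn(Cc3ccc(C(=O)NC4CCCC4)cc3)c(=O)c3ccccc23)cn1`, differs from compound 2 by cyclopentyl in place of 1-methylpiperidin-4-yl on an amide-type nitrogen. Going by the values given here, the one step that bears on this, a 1.1-fold higher number from compound 1 to compound 2 (0.03 log units; within the scatter), also changed the amide substituent on that carbonyl and stayed within the scatter, so no step beyond the scatter is expected here, as a 1.0-fold lower number from compound 2 to compound 3 (0.02 log units; within the scatter). Compound 3 is therefore estimated at 80000 nM, between 30000 nM and 200000 nM.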

Compound 3, half-maximal inhibitory concentration: 23700 nM
Compound 3: middle estimate off by 3.4-fold (0.53 log units), on the high side; the whole stated range lies above it.
By their numbers in this assay, from the lowest: compound 3; then compounds 1 and 2 (each within the scatter of the next).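

Cyclopentyl on the amide-type nitrogen brings the first change beyond the scatter in this assay, with (a 3.5-fold lower number from compound 2 to compound 3 (0.55 log units; beyond the scatter)) and (a 3.3-fold lower number from compound 1 to compound 3 (0.51 log units; beyond the scatter)). The substituent on this carbonyl therefore does move the number, although the earlier swap of piperidin-1-yl for (1-methylpiperidin-4-yl)amino did not show it. Nothing on hand explains this gain.

On these data alone, whether it is specific to cyclopentyl remains open. Cyclohexyl, cyclobutyl or an open chain such as n-butyl on the same nitrogen could show whether the number falls further.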